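Three amides and a methyl on one shared core

This account rests on a few compounds, and the source may have more. Where it says the series, first, only, none or still open, it means among the compounds named here.

Compound 1 `CN1CCc2nc(C#Cc3ccccc3)sc2C1` carries a methyl on the amine nitrogen in the ring of its shared core. In an assay on HEK293 cells for negative allosteric modulation of metabotropic glutamate receptor 5 (Homo sapiens), read by FLIPR, with a stated time of 1 h (a lower number here means a stronger inhibitor, a higher number a weaker inhibitor), compound 1 gives > 10000 nM, which is a limit of the assay rather than a number. Compound 2 `COC1CC(C(=O)N2CCc3nc(C#Cc4ccccc4)sc3C2)C1` replaces that methyl with a (3-methoxycyclobutyl)carbonyl group; in this assay compound 2 gives > 10000 nM, again a limit. Compound 3 `O=C(C1CCCC1)N1CCc2nc(C#Cc3ccccc3)sc2C1` bears a cyclopentylcarbonyl group instead; in this assay compound 3 gives > 10000 nM, also a limit. The step that the two limits leave unreadable from compound 1 to compound 2 and the step that the two limits leave unreadable from compound 1 to compound 3 therefore cannot be read in size, and the same holds for a step that the two limits leave unreadable from compound 2 to compound 3, because of the limit of > 10000 nM in this assay, at which 3 of the 3 values shown sit. Compound 4 `O=C(C1CCOCC1)N1CCc2nc(C#Cc3ccccc3)sc2C1` is the next member of this small set, and its change from compound 1 is (oxan-4-yl)carbonyl in place of methyl on an amine nitrogen in a ring. The two amides already measured, compound 2 and compound 3, both sit at the limit, and neither gives a reading that would set a direction for a third amide on the same nitrogen. Compound 4 is therefore expected to remain at the limit as well, with an estimated value of 15000 nM and a range from 5000 nM to 50000 nM. The step that the limit leaves unreadable from compound 1 to compound 4 is accordingly estimated to be unreadable against the limit.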

Compound 4, half-maximal inhibitory concentration: > 10000 nM
Compound 4: no number, only a limit; the forecaster's own chance of this, stated with the estimate: 85%; the middle value does not contradict the limit.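

In this assay compound 4 gives > 10000 nM as a limit of the assay and not a number. Within the data shown here, no step linking compound 4 with compound 1, compound 2 or compound 3 can be read in size, because all four compounds stand at one limit: the limit of > 10000 nM in this assay, at which 4 of the 4 values shown sit. The compounds shown leave open whether any group on this ring nitrogen gives a measurable inhibition in this assay.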